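Solubility When the Aromatic Group on the Chain Carbon Changes

The source may report more compounds than this note shows. Statements on the series, on what has been measured and on what is new or still open speak of the compounds shown alone.

compound 1: `CNC(=O)c1cc(C(=O)NC2CC2)cn([C@H](C)c2ccccc2)c1=O`, >= 168 ug/mL
compound 2: `CNC(=O)c1cc(C(=O)NC2CC2)cn(Cc2cccc(C)c2)c1=O`, >= 205 ug/mL

In a physicochemical assay for solubility (a higher number here means a more soluble compound, a lower number a less soluble compound), compound 1 gives >= 168 ug/mL, which is a limit of the assay and not a number. In this assay compound 2 gives >= 205 ug/mL, again a limit. The step that the two limits leave unreadable from compound 1 to compound 2 therefore cannot be sized because the limit of >= 168 ug/mL in this assay, at which 1 of the 2 values shown sits, and the limit of >= 205 ug/mL in this assay, at which 1 of the 2 values shown sits, cap both values. Among the measured compounds shown here, compound 2 thus stands at a limit, and the one other value shown is also a limit, so no measured step gives a readable size. Compound 3 `CNC(=O)c1cc(C(=O)NC2CC2)cn(Cc2cccc3cc[nH]c23)c1=O` differs from compound 2 in one place: 1H-indol-7-yl in place of 3-methylphenyl on a saturated chain carbon bound to an aromatic nitrogen. For the measured compounds named here, no measured step bears on this change, so the expected step of an at least 1.3-fold lower number from compound 2 to compound 3 (0.13 log units; that floor lies within the scatter) is estimated without a measured precedent, in no firm direction. Compound 3 is expected to give about 150 ug/mL, within 50 ug/mL to 300 ug/mL.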

Compound 3, solubility: >= 144 ug/mL
Compound 3 was reported as a limit (the forecaster's own chance of this, stated with the estimate: 45%); the middle value does not contradict the limit.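

In this assay compound 3 gives >= 144 ug/mL, which is a limit of the assay and not a number. Compound 2 also stands at a limit, so no step can be read between compound 2 and compound 3. The compounds shown leave open whether 1H-indol-7-yl in place of 3-methylphenyl changes the solubility read-out at all, and in which direction.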